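The compounds below may be only part of what the source reports. "The series", "measured", "known", "first", "only" and "open" are said of these compounds alone.

Three compounds have so far been measured in an assay on isolated protein for inhibition of protein kinase C delta type (Homo sapiens), read by TR-FRET, with a stated time of 2 h; a lower number here means a stronger inhibitor, a higher number a weaker inhibitor:

compound 1, `N#Cc1cnc(NCc2cnccc2C(F)(F)F)cc1NC1CCOCC1`, gives 9800 nM;
compound 2, `N#Cc1cnc(NCc2cnccc2C(F)(F)F)cc1N[C@H]1CC[C@@H](n2cncn2)CC1`, gives 5500 nM;
compound 3, `N#Cc1cnc(NCc2cncnc2C(F)(F)F)cc1N[C@H]1CC[C@@H](O)CC1`, gives 450 nM.

Compound 3 stands at the lowest number of the three, and so is the strongest inhibitor here: its gap to compound 2, the nearest, lies beyond the usual scatter, and the gap to compound 1, the furthest, is wider still. Compound 4, `COc1ncncc1CNc1cc(N[C@H]2CC[C@@H](O)CC2)c(C#N)cn1`, keeps everything in compound 3 except one group: methoxy in place of trifluoromethyl on an aromatic carbon. For the measured compounds named here, no measured pair shows this kind of exchange, so no step can be quoted for it; the three measured compounds differ elsewhere in the molecule. With nothing to lean on, the expectation is a modest rise in the number, probably just beyond the scatter, although a change in either direction cannot be ruled out. For compound 4 the estimated step is a 2.2-fold higher number from compound 3 to compound 4 (0.35 log units; beyond the scatter). Compound 4 is thus expected at 1000 nM, within a range from 250 nM to 4000 nM.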

Compound 4, half-maximal inhibitory concentration: 800 nM
For compound 4 the middle estimate is 1.3-fold (0.10 log units) above the measured one; the range from low to high includes it.
By their numbers in this assay, from the lowest: compounds 3 and 4 (each within the scatter of the next); then compounds 2 and 1 (each within the scatter of the next).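

In this assay, methoxy in place of trifluoromethyl gives a 1.8-fold higher number from compound 3 to compound 4 (0.25 log units; within the scatter), so this pair cannot be told apart by the assay. For the compounds shown here, this is the first sign that the aromatic carbon next to the ring nitrogen can carry either group with no change beyond the scatter, even though methoxy has fewer heavy atoms and adds a hydrogen-bond acceptor. No measurement shown here explains why the two groups read alike.

As far as these compounds go, with only these two groups compared at this position, it remains open how an amine, a chlorine atom or a longer chain such as ethoxy would read there. Also open, from the compounds shown here alone, is whether the same exchange would read alike in compounds that differ elsewhere in the molecule, such as compound 1 or compound 2.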